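Methoxycarbonyl Replacing Amino on the Saturated Chain

A few compounds are considered here, and "the series" means these few. Any claim that something is new, unique, unknown or untested is made for them only; others in the source may bear on it.

Compound 2 `COc1ccc(F)cc1-c1cccc(-c2nn(CCCN)c(=O)o2)c1` stands lowest of the two measured numbers: in a functional assay on the whole organism (strain Wistar albino) for inhibition, with Rattus norvegicus as the target, read by paw edema, with stated times of 30 min and 1.5 h, at a dose of 10 mg/kg by the oral route (on this read-out lower numbers stand for less inhibition and higher numbers for more inhibition at the one dose given (going by the name of the read-out)), compound 2 gives 55%, while compound 1 `COc1ccc(F)cc1-c1cccc(-c2nn(CCCCF)c(=O)o2)c1` gives 67%. Within the data shown here, the one measured step is a number 12 percentage points lower from compound 1 to compound 2 (beyond the scatter). Compound 3 `COC(=O)CCCn1nc(-c2cccc(-c3cc(F)ccc3OC)c2)oc1=O` differs from compound 2 by methoxycarbonyl in place of amino on a saturated chain carbon, three bonds along the chain from an aromatic nitrogen. Among the measured compounds shown here, no measured step covers this change directly; since the step with a number 12 percentage points lower from compound 1 to compound 2 (beyond the scatter) accompanied the entry of the amino group that now leaves, a modest step upward is expected for compound 3, with a number 7 percentage points higher from compound 2 to compound 3 (within the scatter). Compound 3 is therefore estimated at 62%, expected to lie between 48% and 76%.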

Compound 3, a percentage reported as inhibition, in the whole organism at one dose (the size of the read-out at that dose, not a potency): 61%
The estimate for compound 3 lay 1 percentage points above the measured number, and the stated range covers the measured number.
By their numbers in this assay, from the lowest: compounds 2, 3 and 1 (each within the scatter of the next, the first and the last beyond it).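

In this assay, putting methoxycarbonyl in place of amino gives a number 6 percentage points higher from compound 2 to compound 3 (within the scatter), and putting it in place of fluoromethyl gives a number 6 percentage points lower from compound 1 to compound 3 (within the scatter). This position therefore accepts a group with no hydrogen-bond donors and more heavy atoms than amino without a step beyond the scatter in either direction, and the new group does not extend the one gap beyond the scatter into a clear order. Nothing measured here explains these numbers.

Going by these compounds, whether a carboxylic acid in place of the methoxycarbonyl, or a longer chain carrying it, would move the number beyond the scatter remains open. With only one dose, the compounds' potency also remains unread.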